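This account rests on a few compounds, and the source may have more. Where it says the series, first, only, none or still open, it means among the compounds named here.

Working notes on the series in an ADME assay on a cell-free system (serum, Bos taurus) for protein binding. Compound 1 `O=C(NNS(=O)(=O)c1ccccc1F)c1cc(F)cc(-n2cccn2)c1` gives 67.2%, and compound 2 `O=C(NNS(=O)(=O)c1ccccc1F)c1cc(F)cc(-c2ccccn2)c1` gives 74.9%. With only these two values, compound 2 cannot be told apart from compound 1, so it has no distinct standing in the series.

Compound 3 `C=CCOc1cc(F)cc(C(=O)NNS(=O)(=O)c2ccccc2F)c1` keeps the shared core but carries allyloxy in place of pyridin-2-yl on an aromatic carbon. The six-membered aromatic ring leaves and a chain with no ring enters, on a carbon meta to a fluoro group.

Within the data shown here, only one measured step bears on this place: a 1.3-fold lower unbound fraction from compound 1 to compound 2 (0.12 log units; within the scatter). That step is small, but both of its groups contain a ring. Among the measured compounds shown here, no measured compound lacks a ring here, so it is only a weak guide to the new change.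

No shift beyond the scatter is expected in this assay, and the data give no firm direction. The expected size is a 1.2-fold higher unbound fraction from compound 2 to compound 3 (0.08 log units; within the scatter). Compound 3 is estimated at 70%, with an expected range of 52% to 84%.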

Compound 3, plasma protein binding: 80.6%
Compound 3: middle estimate off by 1.5-fold (0.19 log units) (unbound fraction), on the high side; measured number inside the range.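

In this assay, among these compounds, this place on an aromatic carbon, meta to a fluoro group, now holds a group with no ring for the first time, and the exchange of pyridin-2-yl for allyloxy reads as a 1.3-fold lower unbound fraction from compound 2 to compound 3 (0.11 log units; within the scatter), so the loss of the six-membered aromatic ring leaves no shift that can be told from the scatter. The exchange of 1H-pyrazol-1-yl for allyloxy, read as a 1.7-fold lower unbound fraction from compound 1 to compound 3 (0.23 log units; within the scatter), also stays within the scatter, so none of the three groups can be ranked against the others, and a ring at this place is not required for the read-out to stay in this range. Nothing at hand bears on the reason for this result.

Going by these compounds, whether an amine, a carboxylic acid or a longer chain at this place would move the read-out in this assay beyond the scatter remains open, as does whether the double bond of allyloxy matters, which a saturated propoxy group would address. The rest of the shared core is constant across compounds 1, 2 and 3, so these compounds say nothing about changes elsewhere on it.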